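A few compounds are considered here, and "the series" means these few. Any claim that something is new, unique, unknown or untested is made for them only; others in the source may bear on it.

Working notes on the series, continued. Compound 1 `COc1ccc(C2CC(c3ccc(OC)c(OC)c3)=NN2C(=O)CBr)c(OC)c1` gives 71% in a functional assay on the whole organism (strain albino) for inhibition, with Rattus norvegicus as the target, read by paw edema, with stated times of 30 min and 3 h, at a dose of 100 mg/kg by the oral route; on this read-out higher numbers stand for more inhibition at the one dose given (going by the name of the read-out) and lower numbers for less inhibition. Compound 2 `COc1ccc(C2CC(c3ccc(OC)c(OC)c3)=NN2C(=O)CO[N+](=O)[O-])c(OC)c1` gives 58%, and compound 3 `COc1ccc(C2=NN(C(=O)C(C)O[N+](=O)[O-])C(c3ccco3)C2)cc1OC` gives 42%. On these three numbers compound 3 stands lowest: compound 2 sits higher and compound 1 sits higher still, and both gaps lie beyond the scatter. Among the compounds with values here, the one step recorded so far, a number 13 percentage points lower from compound 1 to compound 2 (beyond the scatter), concerns the chain on the carbonyl and not the ring substituent, so it does not bear directly on the change now in question.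

Compound 4 `COc1ccc(C2CC(c3ccc(OC)c(OC)c3)=NN2C(=O)C(C)O[N+](=O)[O-])c(OC)c1` is the next member. It differs from compound 3 by 2,4-dimethoxyphenyl in place of furan-2-yl on a saturated ring carbon. Within the data shown here, no measured pair shows this exchange, so the expectation rests on the spread of the numbers at hand: compound 4 carries the same 2,4-dimethoxyphenyl as compound 2, which gives 58%, and it is expected to land nearer that figure than the low number of compound 3. For compound 4 an inhibition of 55% is therefore estimated, within 40% to 70%, which means an expected step of a number 13 percentage points higher from compound 3 to compound 4 (beyond the scatter).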

Compound 4, a percentage reported as inhibition, in the whole organism at one dose (the size of the read-out at that dose, not a potency): 56%
Compound 4: the middle estimate sits 1 percentage points below what was measured, within the range that was stated.
By their numbers in this assay, from the lowest: compound 3; then compounds 4 and 2 (each within the scatter of the next); then compound 1.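

In this assay, the exchange on the saturated ring carbon now has a measured size: 2,4-dimethoxyphenyl in place of furan-2-yl gives a number 14 percentage points higher from compound 3 to compound 4 (beyond the scatter). On the chain, methyl in place of hydrogen gives a number 2 percentage points lower from compound 2 to compound 4 (within the scatter), so that change leaves no readable difference, while 1-(nitrooxy)ethyl in place of bromomethyl gives a number 15 percentage points lower from compound 1 to compound 4 (beyond the scatter). Nothing at hand accounts for either the ring or the chain result.

From the compounds shown here alone, the ring carbon rests on a single pair, so it remains open whether the higher number follows the six-membered aromatic ring or its methoxy groups, and how a plain phenyl or a pyridine would read there. Also open, going by these compounds, is how an amine or a longer chain would read in place of 1-(nitrooxy)ethyl on the carbonyl.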